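The source may hold more compounds than are shown below. What is called first, only, known or untested is meant among the compounds shown, and "the series" means these compounds.

Compound 2 `Cc1ccc(S(=O)(=O)NC(=O)Nc2ccccc2C(=O)/C=C/c2cccc(O)c2)cc1` stands highest of the three numbers in an ADME assay on the whole organism for cytotoxicity, with Artemia salina as the target, with a stated time of 24 h (on this read-out lower numbers stand for an effect already at smaller amounts and higher numbers for an effect only at larger amounts of compound), where compound 2 gives 39.3 ug/mL. Compound 1 `COc1ccc(/C=C/C(=O)c2ccccc2NC(=O)NS(=O)(=O)c2ccc(C)cc2)c(OC)c1` gives 16 ug/mL in this assay, and compound 3 `C=CCOc1ccc(/C=C/C(=O)c2ccccc2NC(=O)NS(=O)(=O)c2ccc(C)cc2)cc1` gives 6.11 ug/mL. All three measured steps change the aryl group on a double-bonded chain carbon bound to a double-bonded chain carbon: a 2.5-fold higher number from compound 1 to compound 2 (0.39 log units; beyond the scatter), a 2.6-fold lower number from compound 1 to compound 3 (0.42 log units; beyond the scatter) and a 6.4-fold lower number from compound 2 to compound 3 (0.81 log units; beyond the scatter). Compound 4 `Cc1ccc(S(=O)(=O)NC(=O)Nc2ccccc2C(=O)/C=C/c2ccc[nH]2)cc1` is not yet measured; its change from compound 2 reads (1H-pyrrol-2-yl in place of 3-hydroxyphenyl on a double-bonded chain carbon bound to a double-bonded chain carbon). Going by the values given here, none of the measured steps brings in 1H-pyrrol-2-yl or a five-membered aromatic ring with 1 hetero atom, so the three steps only set the scale: each swap of the aryl group at this place moved the number modestly, and both steps that touch compound 2 leave 3-hydroxyphenyl with the highest number. A modest downward step in this assay is therefore expected, though a result within the scatter cannot be excluded. For compound 4 the expected step is a 1.8-fold lower number from compound 2 to compound 4 (0.25 log units; within the scatter). Compound 4 is estimated at 22 ug/mL, within 8 ug/mL to 60 ug/mL.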

Compound 4, concentration for half-maximal effect: 32.1 ug/mL
Beside the measured number, compound 4's estimate is 1.5-fold (0.16 log units) below it; measured number inside the range.
By their numbers in this assay, from the lowest: compound 3; then compounds 1, 4 and 2 (each within the scatter of the next, the first and the last beyond it).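

In this assay, the first five-membered aromatic ring with 1 hetero atom at this place, on a double-bonded chain carbon bound to a double-bonded chain carbon, is not separated from 3-hydroxyphenyl (a 1.2-fold lower number from compound 2 to compound 4 (0.09 log units; within the scatter)) or from 2,4-dimethoxyphenyl (a 2.0-fold higher number from compound 1 to compound 4 (0.30 log units; within the scatter)). Among the four aryl groups, only 4-(allyloxy)phenyl stands clear of 1H-pyrrol-2-yl (a 5.3-fold higher number from compound 3 to compound 4 (0.72 log units; beyond the scatter)), so compound 3 remains the one compound here apart from this group of values. No measurement bears on why these numbers fall as they do.

Open, on these data alone, is whether a furan-2-yl or thiophen-2-yl ring at this place would read like 1H-pyrrol-2-yl. Also open, as far as these compounds go, is how the number responds to a phenyl ring carrying an amine, a carboxylic acid or an alkoxy chain longer than allyloxy.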